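Aryl swap at the arylidene: compound 3 to compound 4

The compounds below may be only part of what the source reports. "The series", "measured", "known", "first", "only" and "open" are said of these compounds alone.

The series shares one core and varies the arylidene group. Compound 1 `C=CCn1c(=O)/c(=C\c2cccc(Cl)c2Cl)[nH]c(=O)/c1=C\c1ccccc1OC` carries a 2,3-dichlorophenyl there and in a functional assay on U-937 cells (Homo sapiens) for cytotoxicity, read by CCK-8 assay, with a stated time of 72 h (on this read-out higher numbers stand for weaker inhibition and lower numbers for stronger inhibition), compound 1 gives 500 nM. Compound 2 `C=CCn1c(=O)/c(=C\c2ccc(Cl)c(Cl)c2)[nH]c(=O)/c1=C\c1ccccc1OC`, with a 3,4-dichlorophenyl, gives "not active" (no number reported) in this assay. Among the measured compounds shown here, compound 3 `C=CCn1c(=O)/c(=C\c2ccccc2C(F)(F)F)[nH]c(=O)/c1=C\c1ccccc1OC`, with a 2-(trifluoromethyl)phenyl, gives 1500 nM in this assay; this is the highest of the two numbers in hand, and the one step that reaches it, a 3.0-fold higher number from compound 1 to compound 3 (0.48 log units; beyond the scatter), lies beyond the scatter.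

Compound 4 `C=CCn1c(=O)/c(=C\c2ccccc2F)[nH]c(=O)/c1=C\c1ccccc1OC` is the next entry. Relative to compound 3 the change is fluoro in place of trifluoromethyl on an aromatic carbon, so the arylidene reads 2-fluorophenyl instead of 2-(trifluoromethyl)phenyl. For the measured compounds named here, no measured pair exchanges trifluoromethyl for fluoro; the only measured step, from compound 1 to compound 3, swaps one whole aryl for another and says nothing about this smaller change. The two dichlorophenyl compounds show that the aryl pattern matters, but they give no direction for compound 4.

Going by the values given here, with no bearing step, no move beyond the scatter is expected, no change at the digits printed from compound 3 to compound 4 (within the scatter), and the range is kept wide. Compound 4 is estimated at 1500 nM in this assay, between 400 nM and 6000 nM.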

Compound 4, half-maximal inhibitory concentration: 5500 nM
Estimate against measurement, compound 4: 3.7-fold (0.56 log units) below; measured number inside the range.
By their numbers in this assay, from the lowest: compound 1; then compound 3; then compound 4.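

In this assay, among the compounds shown here, the step from trifluoromethyl to fluoro on an aromatic carbon, ortho to a large group, is a 3.7-fold higher number from compound 3 to compound 4 (0.56 log units; beyond the scatter); it is the first measured step that changes only this one substituent, and it shows that the number responds to the substituent alone, not just to a swap of the whole aryl. The step of an 11-fold higher number from compound 1 to compound 4 (1.04 log units; beyond the scatter) is the largest in hand and places the 2-fluorophenyl arylidene as the weakest of the three compounds with numbers, while compound 2 has no number and cannot be placed in that order. No measured property of these groups is available to account for either step.

From the compounds shown here alone, whether the number follows the size of the group at this aromatic carbon remains open, since one pair cannot fix a trend and a single chloro, a methyl or a nitrile there would be needed to test it. Also open, going by these compounds, is whether an amine or a carboxylic acid at the same place would be tolerated, and whether the order seen here would hold with a longer chain in place of the allyl group on the shared core.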